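Swapping a para fluorine for methoxy on the benzylamine arm

The compounds below may be only part of what the source reports. "The series", "measured", "known", "first", "only" and "open" are said of these compounds alone.

Three compounds share a core in which a benzyl group is joined through an amine to the ring system, and they differ only in the substituents on that benzyl ring. Compound 1 `Nc1cc(N)c2nc(-c3ccccc3)c(NCc3ccc(Cl)c(Cl)c3)nc2c1` gives 30200 nM in a functional assay on 786-0 cells (Homo sapiens) for inhibition, read by sulforhodamine B assay, with a stated time of 48 h; on this read-out lower numbers stand for stronger inhibition of growth and higher numbers for weaker inhibition of growth. Compound 2 `COc1ccc(CNc2nc3cc(N)cc(N)c3nc2-c2ccccc2)cc1OC` gives 34700 nM in this assay, and compound 3 `Nc1cc(N)c2nc(-c3ccccc3)c(NCc3ccc(F)cc3)nc2c1` gives 61700 nM. Compound 3 thus stands at the highest of the three numbers: the step of a 2.0-fold higher number from compound 1 to compound 3 (0.31 log units; beyond the scatter) is modest but beyond the scatter, whereas the step of a 1.8-fold higher number from compound 2 to compound 3 (0.25 log units; within the scatter) is within it, and the step of a 1.1-fold higher number from compound 1 to compound 2 (0.06 log units; within the scatter) is also within the scatter.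

Compound 4 `COc1ccc(CNc2nc3cc(N)cc(N)c3nc2-c2ccccc2)cc1` is compound 3 with one alteration: methoxy in place of fluoro on an aromatic carbon. The closest guide is compound 2, which carries a methoxy at the same place together with a second one, and its number is within the scatter of compound 3. Compound 1 shows that a change in this ring can move the number beyond the scatter, but only modestly. The step from compound 3 to compound 4 is therefore expected to be small and, if anything, toward a lower number, a 1.5-fold lower number from compound 3 to compound 4 (0.17 log units; within the scatter), while remaining within the scatter. Compound 4 is accordingly estimated at 42000 nM in this assay, with a range from 20000 nM to 85000 nM.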

Compound 4, concentration for total growth inhibition: 41700 nM
The estimate for compound 4 lay 1.0-fold (0.00 log units) above the measured number, within the range that was stated.
By their numbers in this assay, from the lowest: compounds 1, 2, 4 and 3 (each within the scatter of the next, the first and the last beyond it).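

In this assay, exchanging fluoro for methoxy on this aromatic carbon, para to a large group, does not separate the two compounds (a 1.5-fold lower number from compound 3 to compound 4 (0.17 log units; within the scatter)). Taking away the second methoxy of compound 2 likewise leaves a step that cannot be told from the scatter (a 1.2-fold higher number from compound 2 to compound 4 (0.08 log units; within the scatter)), and 4-methoxyphenyl in place of 3,4-dichlorophenyl does the same (a 1.4-fold higher number from compound 1 to compound 4 (0.14 log units; within the scatter)), so compound 4 sits within the scatter of all three earlier compounds and only compound 1 and compound 3 remain apart among the four. The compounds shown offer no independent measurement that could explain why these changes in the benzyl ring move the number so little.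

As far as these compounds go, whether an amine or a carboxylic acid on this aromatic carbon, or a longer chain such as butoxy in place of methoxy, would carry the number beyond the scatter of compound 4 stays open. Also open, from the compounds shown here alone, is whether a change away from this ring, for example a pyridine in place of the phenyl on the shared core, would shift the number further than any substitution seen here.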